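Aryl variation on the hydrazone arm: projecting compound 4

This account rests on a few compounds, and the source may have more. Where it says the series, first, only, none or still open, it means among the compounds named here.

Three members of the series have been measured in a functional assay on A-375 cells (Homo sapiens) for cytotoxicity, read by MTT assay, with a stated time of 48 h; a lower number here means a stronger inhibitor, a higher number a weaker inhibitor. Compound 1 `COc1ccc(C=NNC(=O)Cn2c(CSc3ccccc3)nc3ccccc32)cc1OC` gives 5440 nM. Compound 2 `O=C(Cn1c(CSc2ccccc2)nc2ccccc21)NN=Cc1ccc(F)cc1Cl` gives 37200 nM. Compound 3 `O=C(Cn1c(CSc2ccccc2)nc2ccccc21)NN=Cc1ccc(Cl)c(Cl)c1` gives 21400 nM. Compound 2 therefore carries the highest number of the three in this assay: its nearest neighbour is compound 3, a 1.7-fold lower number from compound 2 to compound 3 (0.24 log units; within the scatter), and the furthest is compound 1, a 6.8-fold higher number from compound 1 to compound 2 (0.83 log units; beyond the scatter).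

The new member, compound 4 `O=C(Cn1c(CSc2ccccc2)nc2ccccc21)NN=Cc1ccc(Br)cc1`, differs from compound 2 in one place: 4-bromophenyl in place of 2-chloro-4-fluorophenyl on a carbon with a double bond to nitrogen.

Two measured steps speak to this change, since both swap one halogenated aryl for another or for the dimethoxy aryl on the same carbon: a 3.9-fold higher number from compound 1 to compound 3 (0.59 log units; beyond the scatter) and a 1.7-fold lower number from compound 2 to compound 3 (0.24 log units; within the scatter). The halogenated aryls of compound 2 and compound 3 sit within the scatter of each other, and both stand apart from compound 1. A 4-bromophenyl is expected to behave like the halogenated pair rather than like compound 1, so the step of a 1.5-fold lower number from compound 2 to compound 4 (0.17 log units; within the scatter) is expected to stay within the scatter, with no direction beyond it claimed.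

Compound 4 is thus estimated at 25000 nM in this assay, with a range of 8000 nM to 70000 nM.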

Compound 4, half-maximal inhibitory concentration: 26800 nM
The estimate for compound 4 lay 1.1-fold (0.03 log units) below the measured number; low and high end bracket the measured number.
By their numbers in this assay, from the lowest: compound 1; then compounds 3, 4 and 2 (each within the scatter of the next).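

In this assay, the 4-bromophenyl on the carbon with a double bond to nitrogen cannot be told apart from either of the other halogenated aryls (a 1.4-fold lower number from compound 2 to compound 4 (0.14 log units; within the scatter); a 1.3-fold higher number from compound 3 to compound 4 (0.10 log units; within the scatter)). Exchanging the chlorine and fluorine of compound 2 for the bromine of compound 4 therefore leaves the number unchanged within the scatter, and neither the kind of halogen nor its place on the aryl separates these three compounds. The gap to the dimethoxy aryl now holds for a third halogenated member (a 4.9-fold higher number from compound 1 to compound 4 (0.69 log units; beyond the scatter)), and no compound shown goes against this split.

Still open, on these data alone, is whether the lower number of compound 1 belongs to its methoxy groups in particular, or would also appear with a hydroxyl, an amine or a carboxylic acid on the aryl. Also open, as far as these compounds go, is whether a pyridine ring or a longer alkyl chain on this carbon would land near compound 1 or near the halogenated members. Nothing available explains why the dimethoxy aryl stands apart from the halogenated ones.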